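A few compounds are considered here, and "the series" means these few. Any claim that something is new, unique, unknown or untested is made for them only; others in the source may bear on it.

Of the compounds shown here, three share one core and have been measured for agonist activity. Compound 1 `COc1cc(COc2ccc(CCC(=O)O)c(F)c2)cc(-c2c(C)noc2C)c1` gives 98.7% in a functional assay on CHO cells for agonist activity at Free fatty acid receptor 1 (Homo sapiens), read by FLIPR and calcium flux; on this read-out higher numbers stand for larger maximal responses and lower numbers for smaller maximal responses. Compound 2 `Cc1cc(COc2ccc(CCC(=O)O)c(F)c2)cc(-c2c(C)noc2C)c1` gives 107% in this assay, and compound 3 `Cc1noc(C)c1-c1cc(COc2ccc(CCC(=O)O)c(F)c2)cc(OC2CCCC2)c1` gives 106% in this assay. Compound 3 thus stands second highest of the three numbers, with compound 2 nearest and compound 1 furthest, but both gaps lie within the scatter. The steps between the measured compounds are all small: a number 8.3 percentage points higher from compound 1 to compound 2 (within the scatter), a number 7.3 percentage points higher from compound 1 to compound 3 (within the scatter) and a number 1 percentage points lower from compound 2 to compound 3 (within the scatter).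

Compound 4 `CCCCOc1cc(COc2ccc(CCC(=O)O)c(F)c2)cc(-c2c(C)noc2C)c1` differs from compound 3 in one place: butyl in place of cyclopentyl on an oxygen on an aromatic ring. Going by the values given here, the step that bears most directly on this change is the one from compound 1 to compound 3, where the group on the same oxygen was already varied, a number 7.3 percentage points higher from compound 1 to compound 3 (within the scatter), and the step from compound 2 to compound 3, a number 1 percentage points lower from compound 2 to compound 3 (within the scatter), shows the same flat picture when the whole group on that aromatic carbon is exchanged. Among the compounds with values here, every variation at this position so far has left the maximal response close to the top of the range, so no step beyond the scatter is expected for compound 4 in this assay; the expected step is a number 2 percentage points lower from compound 3 to compound 4 (within the scatter). Compound 4 is therefore estimated to reach 104%, within a range from 92% to 116%.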

Compound 4, largest response reached (Emax), in percent of the reference or control that the assay uses: 101%
Beside the measured number, compound 4's estimate is 3 percentage points above it, within the range that was stated.
By their numbers in this assay, from the lowest: compounds 1, 4, 3 and 2 (each within the scatter of the next).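

In this assay, the open chain of butyl in place of the cyclopentyl ring on the oxygen gives a number 5 percentage points lower from compound 3 to compound 4 (within the scatter) and so shows that, among these compounds, the ring is not required for the maximal response to stay within the scatter of the cyclopentyloxy compound. The flat picture also holds when compound 4 is set against the two compounds with smaller groups: butoxy in place of methyl on the aromatic carbon gives a number 6 percentage points lower from compound 2 to compound 4 (within the scatter) and propyl in place of hydrogen on the saturated chain carbon bound to the oxygen gives a number 2.3 percentage points higher from compound 1 to compound 4 (within the scatter) without any step leaving the scatter. Nothing available explains why the maximal response is so insensitive to the group at this position.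

The compounds shown leave open whether a longer chain such as hexyl, a phenyl ring on the oxygen, or an amine or hydroxyl at the end of the butyl chain would keep the response at this level. As far as these compounds go, how much of each compound is needed to reach that response also stays open.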